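One Double Bond Redrawn in Compound 3

The compounds below may be only part of what the source reports. "The series", "measured", "known", "first", "only" and "open" are said of these compounds alone.

In an ADME assay on HFF cells (Homo sapiens) for cytotoxicity, read by neutral red uptake (a lower number here means that less compound is tolerated, a higher number that more compound is tolerated), compound 1 (`Nc1ncnc2c1ncn2/C=C1/C[C@H]1[C@H](O)CO`) gives 206000 nM and compound 2 (`Nc1ncnc2c1ncn2/C=C1\C[C@H]1[C@@H](O)CO`) gives 264000 nM, so these two values lie within the scatter of each other. Compound 3 (`Nc1ncnc2c1ncn2/C=C1/C[C@H]1[C@@H](O)CO`) departs from compound 2 in one place: the two compounds have the same atoms and bonds and differ only in configuration as drawn: 1 of 3 stereo elements differ; a double bond is drawn E in compound 2 and Z in compound 3. Among the measured compounds shown here, one measured step bears on this, a 1.3-fold higher number from compound 1 to compound 2 (0.11 log units; within the scatter), and it changes this double bond together with a stereocentre. For the measured compounds named here, with only that small step as a guide, the expected change in this assay is a 1.1-fold lower number from compound 2 to compound 3 (0.06 log units; within the scatter), with no direction beyond the scatter. Compound 3 is estimated at 230000 nM, with an expected range of 120000 nM to 420000 nM.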

Compound 3, half-maximal cytotoxic concentration: 194000 nM
Compound 3: the middle estimate sits 1.2-fold (0.07 log units) above what was measured; low and high end bracket the measured number.
By their numbers in this assay, from the lowest: compounds 3, 1 and 2 (each within the scatter of the next).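

Each change can now be read alone in this assay. Redrawing the double bond gives a 1.4-fold lower number from compound 2 to compound 3 (0.13 log units; within the scatter), and redrawing the stereocentre at the saturated chain carbon gives a 1.1-fold lower number from compound 1 to compound 3 (0.03 log units; within the scatter). Compounds 1 and 2 differed at both places at once, whereas these steps show that neither change alone takes the number beyond the scatter.

All three compounds have the same atoms and bonds, so they say nothing about a different group. Going by these compounds, what an amine or a longer chain would do in this assay stays open.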